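The compounds below may be only part of what the source reports. "The series", "measured", "known", "first", "only" and "open" are said of these compounds alone.

Compound 1 `O=C(Nc1cccc(-n2cc(-c3ccncc3)c(-c3ccc(Cl)c(O)c3)n2)c1)Nc1cccc(C(F)(F)F)c1` in a functional assay on T47D cells (Homo sapiens) for inhibition, read by sulforhodamine B assay, with a stated time of 48 h (a lower number here means that less compound is tolerated, a higher number that more compound is tolerated), gives > 32500 nM, which is a limit of the assay rather than a number.
Compound 2 `O=C(Nc1cccc(-n2cc(-c3ccncc3)c(-c3ccc(Cl)c(O)c3)n2)c1)Nc1ccc(Cl)c(Cl)c1` in this assay gives > 32500 nM, again a limit of the assay.
Compound 3 `COc1cc(-c2nn(-c3cccc(NC(=O)Nc4ccc(Cl)c(C(F)(F)F)c4)c3)cc2-c2ccncc2)ccc1Cl` in this assay gives > 32500 nM, also a limit of the assay.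

All three measured compounds sit at the same point, (the limit of > 32500 nM in this assay, at which 3 of the 3 values shown sit), so none of them has a readable value and no ranking among them is possible. Within the data shown here, the only measured pair that differs in one place is the step that the two limits leave unreadable from compound 1 to compound 2. Both of its ends are limits, and its size cannot be read. Compound 3 thus stands at the limit, with no number of its own.

The change that leads to compound 4 `O=C(Nc1cccc(-n2cc(-c3ccncc3)c(-c3ccc(Cl)c(O)c3)n2)c1)Nc1ccc(Cl)c(C(F)(F)F)c1` is hydrogen in place of methyl on an oxygen on an aromatic ring. Among the measured compounds shown here, no measured step bears directly on this kind of change, and the one step that exists is itself unreadable. What the data give is that every tested variant of the shared core, including compound 3, tolerated the highest concentration tested. It is therefore expected that compound 4 also reaches the limit, meaning the estimated step that the limit leaves unreadable from compound 3 to compound 4 is not beyond the scatter. Compound 4 is estimated at 45000 nM, with a range from 15000 nM to 150000 nM.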

Compound 4, concentration lethal to 50% of the cells: > 32500 nM
Compound 4: only a limit was reported; the forecaster's own chance of this, stated with the estimate: 80%; the middle value does not contradict the limit.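

Compound 4 also stands at a limit of the assay, like compound 1, compound 2 and compound 3, so none of the steps among these compounds can be read: the limit of > 32500 nM in this assay, at which 4 of the 4 values shown sit. In this assay the compounds shown leave open whether any of these changes alters the concentration lethal to the cells, and by how much.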